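The compounds below may be only part of what the source reports. "The series", "measured", "known", "first", "only" and "open" are said of these compounds alone.

In a functional assay on B16 cells (Mus musculus) for inhibition (a higher number here means a weaker inhibitor, a lower number a stronger inhibitor), compound 1 `COC(=O)[C@]1(O)C[C@@H](O)[C@@H](O)[C@H](OC(=O)/C=C/c2ccc(O)c(O)c2)C1` gives > 40000 nM, and this value is a limit of the assay. Compound 2 `CC(C)c1ccc(NC(=O)/C=C/c2ccc(O)c(O)c2)cc1` reads 3400 nM. Compound 3 `Cc1ccccc1CNC(=O)/C=C/c1ccc(O)c(O)c1` reads 20000 nM, the higher of the two actual numbers, and its gap to compound 2 lies beyond the scatter. Compound 4 `O=C(/C=C/c1ccc(O)c(O)c1)NCc1ccccc1Cl` differs from compound 3 by a single change, chloro in place of methyl on an aromatic carbon, ortho to a large group. Going by the values given here, no measured pair isolates this kind of change, so the expectation starts from compound 3 at 20000 nM. The expected step in this assay is a 1.3-fold lower number from compound 3 to compound 4 (0.10 log units; within the scatter), with none beyond the scatter. For compound 4 the estimated value is 16000 nM, with an expected range of 7000 nM to 35000 nM.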

Compound 4, half-maximal inhibitory concentration: 6500 nM
The estimate for compound 4 lay 2.5-fold (0.39 log units) above the measured number; the measured number lies below the stated range.
By their numbers in this assay, from the lowest: compounds 2 and 4 (each within the scatter of the next); then compound 3. At a limit, above all of these: compound 1.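

In this assay, going by these compounds alone, the change from 2-methylphenyl to 2-chlorophenyl gives the first step that isolates one place: a 3.1-fold lower number from compound 3 to compound 4 (0.49 log units; beyond the scatter). The group on this aromatic carbon, ortho to a large group, therefore moves the number beyond the scatter, which compound 1, compound 2 and compound 3 could not show, as no two of them differ in one place. No measured property shown here bears on the reason for this step.

Open, as far as these compounds go, is what a bromo, methoxy or amine group in the same place would give. Also open, from the compounds shown here alone, is whether a chloro in place of methyl gives a similar step on other compounds.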